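Trimming the Side Chain Back to a Bare Hydroxy Group

The compounds below may be only part of what the source reports. "The series", "measured", "known", "first", "only" and "open" are said of these compounds alone.

Compound 1 `COc1ccc(C(O)(Cc2ccc(F)cc2)c2cccc3ccccc23)c(OC)c1OC`: 7560 nM in a functional assay on MCF7 cells (Homo sapiens) for inhibition, read by sulforhodamine B assay, with a stated time of 48 h; a higher number here means a weaker inhibitor, a lower number a stronger inhibitor
Compound 2 `COc1ccc(C(c2ccc(OC(C)CN(C)C)cc2)c2cccc3ccccc23)c(OC)c1OC`: 13100 nM in this assay
Compound 3 `COc1ccc(C(c2ccc(OCCO)cc2)c2cccc3ccccc23)c(OC)c1OC`: only a limit of this assay is known, > 20000 nM

Compound 3 therefore stands at the upper edge of what this assay can report, a limit rather than a number, (the limit of > 20000 nM in this assay, at which 1 of the 3 values shown sits). Compound 4 `COc1ccc(C(c2ccc(O)cc2)c2cccc3ccccc23)c(OC)c1OC` differs from it by hydrogen in place of 2-hydroxyethyl on an oxygen on an aromatic ring. Within the data shown here, the single measured step, an at least 1.5-fold higher number from compound 2 to compound 3 (0.18 log units; that floor lies within the scatter), changed the group on the same oxygen and ran up to the limit, so it shows only that changes there can leave the number at the limit; no step removes the group entirely. The expected step of an at least 1.3-fold lower number from compound 3 to compound 4 (0.12 log units; that floor lies within the scatter) in this assay is therefore modest, with no direction beyond the scatter. Compound 4 is estimated at 15000 nM, between 5000 nM and 45000 nM.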

Compound 4, half-maximal inhibitory concentration: 17500 nM
For compound 4 the middle estimate is 1.2-fold (0.07 log units) below the measured one; the range from low to high includes it.
By their numbers in this assay, from the lowest: compounds 1, 2 and 4 (each within the scatter of the next, the first and the last beyond it). At a limit, above all of these: compound 3.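

Taking the whole group off the oxygen gives a measured number where the 2-hydroxyethyl group gave only a limit, so the bare 4-hydroxyphenyl form can be read in this assay. Removing 2-hydroxyethyl gives an at least 1.1-fold lower number from compound 3 to compound 4 (0.05 log units; that floor lies within the scatter), and the comparison with the dimethylamino-bearing chain gives a 1.3-fold higher number from compound 2 to compound 4 (0.13 log units; within the scatter), so neither step shows a real change. Compound 3 itself remains a limit, not a number: the limit of > 20000 nM in this assay, at which 1 of the 4 values shown sits.

The compounds shown leave open whether a carboxylic acid or a longer chain on this oxygen would move the number beyond the scatter.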